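Second Methoxy on the Pendant Ring of Compound 3

The compounds below may be only part of what the source reports. "The series", "measured", "known", "first", "only" and "open" are said of these compounds alone.

Compound 1 `COc1ccccc1/C=C1\CCc2cc(OC)c(OC)cc2C1=O` and compound 2 `COc1cc2c(cc1OC)C(=O)/C(=C/c1c(OC)cccc1OC)CC2` share a core and differ by one change, (methoxy in place of hydrogen on an aromatic carbon). In a functional assay on Jurkat cells (Homo sapiens) for antiproliferative activity, read by MTT assay (on this read-out lower numbers stand for stronger inhibition and higher numbers for weaker inhibition), compound 1 reaches only a limit, > 50000 nM. Compound 2 likewise reaches only a limit, > 50000 nM. Their step, a step that the two limits leave unreadable from compound 1 to compound 2, stays unreadable because of the limit of > 50000 nM in this assay, at which 2 of the 3 values shown sit. Compound 3 `COc1cccc(/C=C2\Cc3cc(OC)c(OC)cc3C2=O)c1` has a different core; the difference between the two cores is not broken down here. In this assay compound 3 gives 12800 nM. Compound 4 `COc1cc(/C=C2\Cc3cc(OC)c(OC)cc3C2=O)cc(OC)c1` adds to compound 3 the same kind of change, (methoxy in place of hydrogen on an aromatic carbon), though here the new group sits meta to a large group rather than ortho to it. The expected step from compound 3 to compound 4 is a 1.6-fold lower number from compound 3 to compound 4 (0.20 log units; within the scatter), a modest one, resting only on compound 3 giving 12800 nM since the earlier step is unreadable. Compound 4 is estimated at 8000 nM, between 2500 nM and 30000 nM.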

Compound 4, half-maximal inhibitory concentration: 3000 nM
For compound 4 the middle estimate is 2.7-fold (0.43 log units) above the measured one; the measured number falls inside the stated range.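

On the core of compound 3, methoxy in place of hydrogen gives a 4.3-fold lower number from compound 3 to compound 4 (0.63 log units; beyond the scatter) in this assay, so on this core the change lowers the number by more than the usual scatter. Within the data shown here, the same kind of change on the core of compound 1 gives no step that can be set beside it, because both of its compounds reach only a limit: the limit of > 50000 nM in this assay, at which 2 of the 4 values shown sit. The result therefore describes one pair on one core and does not show that the change carries over from one core to another.

On these data alone, it remains open whether a readable step would appear on the core of compound 1 with the methoxy meta to a large group. As far as these compounds go, it is also open how an amine or an ethoxy group at that place would compare with methoxy.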